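This account rests on a few compounds, and the source may have more. Where it says the series, first, only, none or still open, it means among the compounds named here.

Series measured in a functional assay on HL-60 cells (Homo sapiens) for antiproliferative activity, read by XTT assay, with a stated time of 72 h; a lower number here means a stronger inhibitor, a higher number a weaker inhibitor:
- Compound 1 `CNc1ncnc2c1c(-c1ccco1)cn2[C@@H]1O[C@H](CO)[C@@H](O)[C@H]1O`: 620 nM
- Compound 2 `Cc1nc(N)c2c(-c3ccoc3)cn([C@@H]3O[C@H](CO)[C@@H](O)[C@H]3O)c2n1`: > 20000 nM

Compound 2 reports only a limit of the assay, > 20000 nM, and no number.

For the measured compounds named here, compound 1, at 620 nM, therefore holds the only actual number and is the sole quantitative reference point. Compound 3 `CNc1ncnc2c1c(I)cn2[C@@H]1O[C@H](CO)[C@@H](O)[C@H]1O` keeps the core of compound 1 and carries iodo in place of furan-2-yl on an aromatic carbon.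

Going by the values given here, no measured step covers this exchange, so the expectation is loose. In this assay, a moderate loss of potency beyond the scatter is expected, with a modest chance that compound 3 reaches the assay limit. The expected change is a 3.2-fold higher number from compound 1 to compound 3 (0.51 log units; beyond the scatter).

For compound 3 the estimate is 2000 nM, with an expected range of 300 nM to 15000 nM.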

Compound 3, half-maximal inhibitory concentration: > 20000 nM
Compound 3 ended at the assay's limit; the forecaster's own chance of this, stated with the estimate: 15%; middle value at least 10-fold (1.00 log units) away from the limit.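

In this assay, exchanging furan-2-yl for iodo on this aromatic carbon, with the rest of the core kept, gives an at least 32-fold higher number from compound 1 to compound 3 (1.50 log units; beyond the scatter). As far as these compounds go, compound 3 gives > 20000 nM, which is a limit of the assay and not a number, so this step marks only the least possible loss and its true size stays unknown. Activity in this pair therefore depends on the group at this carbon, and a lone iodo does not retain what the five-membered aromatic ring of compound 1 gives, though the reading is capped by the limit: the limit of > 20000 nM in this assay, at which 2 of the 3 values shown sit.

From the compounds shown here alone, whether a phenyl ring or a simple amine on this carbon would retain activity stays open. For the compounds shown here, compound 2 differs from compound 1 in more than one place, so no step involving it can be read.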